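Chalcone-Pyrazole Series: Swapping Methoxyphenyl for Difluorophenyl

The source may report more compounds than this note shows. Statements on the series, on what has been measured and on what is new or still open speak of the compounds shown alone.

Compound 1 `COc1ccc(C(=O)/C=C/c2cc(-c3cc(OC)c(OC)c(OC)c3)n[nH]2)cc1OC`: 270 nM
Compound 2 `COc1ccc(C(=O)/C=C/c2cc(-c3cc(OC)c(OC)c(OC)c3)n[nH]2)cc1`: 340 nM

In a functional assay on SR cells (Homo sapiens) for inhibition, read by sulforhodamine B assay, with a stated time of 48 h (a lower number here means a stronger inhibitor of growth, a higher number a weaker inhibitor of growth), compound 2 gives 340 nM, the highest of the two numbers, with compound 1 nearest at 270 nM. Going by the values given here, the only measured step, a 1.3-fold higher number from compound 1 to compound 2 (0.10 log units; within the scatter), changed the same ring that is altered here and stayed within the scatter. Compound 3 `COc1cc(-c2cc(/C=C/C(=O)c3ccc(F)c(F)c3)[nH]n2)cc(OC)c1OC` differs from compound 2 by 3,4-difluorophenyl in place of 4-methoxyphenyl on a carbonyl carbon. Among the compounds with values here, no measured step shows the effect of fluorine on that ring, so only a small step is expected, a 1.3-fold higher number from compound 2 to compound 3 (0.12 log units; within the scatter). Compound 3 is estimated at 450 nM, within 150 nM to 1400 nM.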

Compound 3, concentration for 50% growth inhibition: 2920 nM
Beside the measured number, compound 3's estimate is 6.5-fold (0.81 log units) below it; measured number above the stated range.
By their numbers in this assay, from the lowest: compounds 1 and 2 (each within the scatter of the next); then compound 3.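

In this assay, the aryl group on the carbonyl carbon proved sensitive to this exchange: 3,4-difluorophenyl in place of 4-methoxyphenyl gave a clear loss (an 8.6-fold higher number from compound 2 to compound 3 (0.93 log units; beyond the scatter)), and in place of 3,4-dimethoxyphenyl a larger one (an 11-fold higher number from compound 1 to compound 3 (1.03 log units; beyond the scatter)). The earlier step between the two methoxy rings had stayed within the scatter, so this position tolerates that difference but not the exchange for the difluorophenyl ring. Nothing available explains this loss. These compounds cannot separate losing methoxy from gaining fluorine. Going by these compounds, whether an unsubstituted phenyl, a hydroxyl or an amine on this ring would behave like methoxy remains open.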